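The source may hold more compounds than are shown below. What is called first, only, known or untested is meant among the compounds shown, and "the series" means these compounds.

Compound 1 `COc1c(O)cc2oc(-c3ccc(O)c(O)c3)c(O[C@@H]3O[C@H](CO)[C@H](O)[C@H](O)[C@H]3O[C@@H]3OC[C@](O)(CO)[C@H]3O)c(=O)c2c1O` and compound 2 `O=C1C[C@@H](c2ccc(O)cc2)Oc2c(O[C@@H]3O[C@H](CO)[C@@H](O)[C@H](O)[C@H]3O)c(O)cc(O)c21` make up the measured part of the series. In a functional assay on cells (Neutrophil, Homo sapiens), read by chemiluminescence, with stated times of 40 min and 2 min (a higher number here means a weaker inhibitor, a lower number a stronger inhibitor), compound 1 gives 7100 nM, the lower of the two numbers; in this assay compound 2 gives 13200 nM, a gap that lies within the usual scatter, so no ordering is claimed. Compound 3 `COc1c(O)cc2oc(-c3ccc(O)c(O)c3)c(O[C@@H]3O[C@H](CO)[C@H](O)[C@H](O)[C@H]3O[C@@H]3OC[C@](O)(CO[C@@H]4OC[C@H](O)[C@H](O)[C@H]4O)[C@H]3O)c(=O)c2c1O` is the next member and differs from compound 1 in one place: 3,4,5-trihydroxyoxan-2-yl in place of hydrogen on an oxygen on a saturated carbon. Going by the values given here, no matched step with a measured pair is available to calibrate this change. A further sugar unit of this kind is expected to leave the number close to that of compound 1, so the step from compound 1 to compound 3 is estimated at a 1.3-fold higher number from compound 1 to compound 3 (0.10 log units; within the scatter). Compound 3 is expected to give 9000 nM, with a range of 3500 nM to 25000 nM.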

Compound 3, half-maximal inhibitory concentration: 5400 nM
Estimate against measurement, compound 3: 1.7-fold (0.22 log units) above; the range from low to high includes it.
By their numbers in this assay, from the lowest: compounds 3, 1 and 2 (each within the scatter of the next, the first and the last beyond it).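

The step to 3,4,5-trihydroxyoxan-2-yl in place of hydrogen on an oxygen on a saturated carbon reads a 1.3-fold lower number from compound 1 to compound 3 (0.12 log units; within the scatter) in this assay, so this oxygen carries a whole further sugar ring with no readable change in the number. Going by these compounds alone, this is the first matched step, and it marks the position as tolerant of this one large group. No measured property bears on this result.

From the compounds shown here alone, whether a methyl group or a carboxylic acid on the same oxygen would shift the number beyond the scatter stays open. So does the effect of removing the outer sugar altogether.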